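Carboxy to (1,3-dicarboxypropyl)carbamoyl on compound 3

The compounds below may be only part of what the source reports. "The series", "measured", "known", "first", "only" and "open" are said of these compounds alone.

In a physicochemical assay for lipophilicity (on this read-out lower numbers stand for lower lipophilicity and higher numbers for higher lipophilicity), compound 1 `COc1ccc(C2=[N+]3C(=Nc4c(-c5ccccc5)c5c(n4[B-]3(F)F)-c3ccc(OCC(=O)O)cc3CC5)C(c3ccccc3)=C2I)cc1` reads 0.94 and compound 3 `COc1ccc2c(c1)CCc1c(-c3ccccc3)c3n(c1-2)[B-](F)(F)[N+]1=C(c2ccc(OCC(=O)O)cc2)C(I)=C(c2ccccc2)C1=N3` reads 0.92, two numbers within the scatter of each other. Compound 2 `COc1ccc(C2=[N+]3C(=Nc4c(-c5ccccc5)c5c(n4[B-]3(F)F)-c3ccc(OCC(=O)N[C@@H](CCC(=O)O)C(=O)O)cc3CC5)C(c3ccccc3)=C2I)cc1` reads -0.74 and lies clearly lower than both, so compound 3 stands with compound 1 at the upper end of the three numbers.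

Compound 4 `COc1ccc2c(c1)CCc1c(-c3ccccc3)c3n(c1-2)[B-](F)(F)[N+]1=C(c2ccc(OCC(=O)N[C@@H](CCC(=O)O)C(=O)O)cc2)C(I)=C(c2ccccc2)C1=N3` is the next structure to be read, with (1,3-dicarboxypropyl)amino in place of hydroxy on a carbonyl carbon as its difference from compound 3: (1,3-dicarboxypropyl)amino in place of hydroxy on a carbonyl carbon. Among the measured compounds shown here, only one measured step bears on this exchange, namely a number 1.68 log units lower from compound 1 to compound 2 (beyond the scatter) as a large change beyond the scatter. For the measured compounds named here, whether it carries over in full to compound 3 is untested, since no second example exists. A step of similar size and the same downward direction is therefore expected in this assay, and the estimated step is a number 1.67 log units lower from compound 3 to compound 4 (beyond the scatter) on this scale. The estimate for compound 4 is -0.75 within an expected range of -1.2 to -0.3 on this scale.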

Compound 4, partition coefficient: -0.71
The estimate for compound 4 lay 0.04 log units below the measured number; measured number inside the range.
By their numbers in this assay, from the lowest: compounds 2 and 4 (each within the scatter of the next); then compounds 3 and 1 (each within the scatter of the next).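

In this assay, the exchange of hydroxy for (1,3-dicarboxypropyl)amino on a carbonyl carbon now has a second example, a number 1.63 log units lower from compound 3 to compound 4 (beyond the scatter), which runs the same way as a number 1.68 log units lower from compound 1 to compound 2 (beyond the scatter). Both steps are large, so the drop is no longer tied to a single pair and holds for both arrangements of the shared core represented by compound 1 and compound 3. The compounds shown offer no measurement that explains the size of this step.

Still open, on these data alone, is how much of the step would remain with a smaller group on the same carbonyl carbon, such as (carboxymethyl)amino or a simple amine. As far as these compounds go, the reading in this assay for a longer dicarboxylic chain, or for the opposite configuration at the defined stereocentre, also remains open.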